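The source may hold more compounds than are shown below. What is called first, only, known or untested is meant among the compounds shown, and "the series" means these compounds.

In a functional assay on NCI-H1975 cells (Homo sapiens) for inhibition, read by MTT assay, with a stated time of 72 h (on this read-out higher numbers stand for weaker inhibition and lower numbers for stronger inhibition), three compounds sharing one core have been measured. Compound 1 `C=CC(=O)Nc1cccc(NC(=O)CSc2nc(Nc3cccc([N+](=O)[O-])c3)c3ccccc3n2)c1` gives 22600 nM, compound 2 `C=CC(=O)Nc1cccc(NC(=O)CSc2nc(Nc3cccc(C)c3)c3ccccc3n2)c1` gives 12100 nM, and compound 3 `C=CC(=O)Nc1cccc(NC(=O)CSc2nc(Nc3ccc(Cl)cc3)c3ccccc3n2)c1` gives 7580 nM. Compound 3 carries the lowest of the three numbers, with a 1.6-fold lower number from compound 2 to compound 3 (0.20 log units; within the scatter) and a 3.0-fold lower number from compound 1 to compound 3 (0.47 log units; beyond the scatter). Compound 4 `C=CC(=O)Nc1cccc(NC(=O)CSc2nc(Nc3ccc(Cl)cc3Cl)c3ccccc3n2)c1` differs from compound 3 by chloro in place of hydrogen on an aromatic carbon. For the measured compounds named here, the steps that bear on it, a 1.9-fold lower number from compound 1 to compound 2 (0.27 log units; within the scatter) and a 1.6-fold lower number from compound 2 to compound 3 (0.20 log units; within the scatter), show that exchanging one substituent on this aromatic ring moves the number little, and only the step of a 3.0-fold lower number from compound 1 to compound 3 (0.47 log units; beyond the scatter) exceeds the scatter. A small step, if any, toward a lower number is therefore expected for compound 4, that is a 1.3-fold lower number from compound 3 to compound 4 (0.10 log units; within the scatter). Compound 4 is estimated at 6000 nM, with a range from 2500 nM to 15000 nM.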

Compound 4, half-maximal inhibitory concentration: 5990 nM
For compound 4 the middle estimate is 1.0-fold (0.00 log units) above the measured one; the measured number falls inside the stated range.
By their numbers in this assay, from the lowest: compounds 4, 3, 2 and 1 (each within the scatter of the next, the first and the last beyond it).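

In this assay, chloro in place of hydrogen on the aromatic carbon ortho to a large group gives a 1.3-fold lower number from compound 3 to compound 4 (0.10 log units; within the scatter), so adding this second chloro shifts the number no further than the scatter. Yet with the 2,4-dichlorophenyl group, a 2.0-fold lower number from compound 2 to compound 4 (0.31 log units; beyond the scatter) and a 3.8-fold lower number from compound 1 to compound 4 (0.58 log units; beyond the scatter) both lie beyond the scatter, whereas the step from compound 2 to compound 3 did not. No measurement available here explains these steps. Going by these compounds, whether a methoxy group or an amine on this aromatic carbon would move the number beyond the scatter remains open.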